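Acetoxyphenyl position and antiproliferative potency in two series

A few compounds are considered here, and "the series" means these few. Any claim that something is new, unique, unknown or untested is made for them only; others in the source may bear on it.

Compound 2 `CC(=O)Oc1ccc(N2C(=O)/C(=C/N3N=C(c4ccccc4)CC3c3ccccc3O)SC2=S)cc1` is tested in a functional assay on SK-OV-3 cells (Homo sapiens) for antiproliferative activity, read by MTT assay, with a stated time of 72 h (a lower number here means a stronger inhibitor, a higher number a weaker inhibitor), where compound 2 gives 244 nM. Compound 1 `CC(=O)Oc1cccc(N2C(=O)/C(=C/N3N=C(c4ccccc4)CC3c3ccccc3O)SC2=S)c1` carries the change (3-acetoxyphenyl in place of 4-acetoxyphenyl on an amide-type nitrogen in a ring). In this assay compound 1 gives only a limit, > 10000 nM. The step is an at least 40-fold higher number from compound 2 to compound 1 (1.61 log units; beyond the scatter), read against (the limit of > 10000 nM in this assay, at which 2 of the 3 values shown sit). Compound 3 `CC(=O)Oc1ccc(N2C(=O)/C(=C/N3N=C(c4ccc5ccccc5c4)CC3c3ccc(Cl)cc3)SC2=S)cc1` is a further member; the difference between the two cores is not broken down here. In this assay compound 3 gives only a limit, > 10000 nM. Compound 4 `CC(=O)Oc1cccc(N2C(=O)/C(=C/N3N=C(c4ccc5ccccc5c4)CC3c3ccc(Cl)cc3)SC2=S)c1` is not yet measured and differs from compound 3 by the same change, (3-acetoxyphenyl in place of 4-acetoxyphenyl on an amide-type nitrogen in a ring). For compound 4 the expected step is a step that the limit leaves unreadable from compound 3 to compound 4. This expectation rests on the step of an at least 40-fold higher number from compound 2 to compound 1 (1.61 log units; beyond the scatter). It also rests on compound 3 giving only a limit, > 10000 nM, in this assay. Compound 4 is therefore expected to give about 30000 nM, between 10000 nM and 100000 nM.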

Compound 4, half-maximal inhibitory concentration: 2390 nM
Beside the measured number, compound 4's estimate is 13-fold (1.10 log units) above it; measured number below the stated range.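

In this assay, the change from 4-acetoxyphenyl to 3-acetoxyphenyl does not carry over from one core to the other, and its direction reverses: the same change on two cores in this assay, an at least 40-fold higher number (1.61 log units; beyond the scatter) from compound 2 to compound 1 and an at least 4.1-fold lower number (0.62 log units; beyond the scatter) from compound 3 to compound 4, at least 170-fold (2.23 log units) apart, beyond the scatter of two such steps On the core of compound 3, the new step is an at least 4.1-fold lower number from compound 3 to compound 4 (0.62 log units; beyond the scatter), so there the 3-acetoxyphenyl compound gives the lower number, whereas on the core of compound 1 it gives the higher one. The true size of neither step is shown, as each rests on a limit: the limit of > 10000 nM in this assay, at which 2 of the 4 values shown sit.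

The compounds shown leave open which of the differences between the two cores goes with the reversal. They also leave open how the step would run on either core with a carboxylic acid or an amine in place of the acetoxy group.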